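Lengthening the Ketone Chain of a Lactone Ketol

The source may hold more compounds than are shown below. What is called first, only, known or untested is meant among the compounds shown, and "the series" means these compounds.

Measured so far:
compound 1 `CCCCCCCCCC(=O)C[C@H](O)C[C@@H]1CC=CC(=O)O1` — 1200 nM
compound 2 `CCCCCCCCCC(=O)C[C@@H](O)C[C@@H]1CC=CC(=O)O1` — 5300 nM

Of the compounds shown here, two have been measured in a functional assay on HL-60 cells (Homo sapiens) for cytotoxicity, read by MTT assay, with a stated time of 24 h; a higher number here means a weaker inhibitor, a lower number a stronger inhibitor. Compound 1 `CCCCCCCCCC(=O)C[C@H](O)C[C@@H]1CC=CC(=O)O1` gives 1200 nM and stands lowest of the two; its nearest neighbour, compound 2 `CCCCCCCCCC(=O)C[C@@H](O)C[C@@H]1CC=CC(=O)O1`, gives 5300 nM. Among the compounds with values here, the single measured step, a 4.4-fold higher number from compound 1 to compound 2 (0.65 log units; beyond the scatter), rests on the fact that compounds 1 and 2 differ only in the configuration as drawn: it turns only on the configuration at a saturated chain carbon and leaves the chain itself untouched.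

Compound 3 `CCCCCCCCCCCC(=O)C[C@H](O)C[C@@H]1CC=CC(=O)O1` has not yet been measured. It differs from compound 1 by ethyl in place of hydrogen on a saturated chain carbon, nine bonds along the chain from a carbonyl carbon. Within the data shown here, no measured step bears on a lengthening of the chain, since the step from compound 1 to compound 2 changes configuration alone and so offers no guide to the size or direction of a change in this assay here. With nothing pointing either way, the expectation is a number close to that of compound 1, within the usual scatter, but with a wide range. Compound 3 is therefore estimated at 1200 nM, between 400 nM and 3600 nM, which means an expected step of no change at the digits printed from compound 1 to compound 3 (within the scatter).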

Compound 3, half-maximal inhibitory concentration: 970 nM
Estimate against measurement, compound 3: 1.2-fold (0.09 log units) above, within the range that was stated.
By their numbers in this assay, from the lowest: compounds 3 and 1 (each within the scatter of the next); then compound 2.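

In this assay, ethyl in place of hydrogen on a saturated chain carbon, nine bonds along the chain from a carbonyl carbon, gives a 1.2-fold lower number from compound 1 to compound 3 (0.09 log units; within the scatter), so the two compounds cannot be told apart here and the lengthened ketone chain is tolerated at this position at this level of resolution. Within the data shown here, the earlier pair spoke only to configuration, with a 4.4-fold higher number from compound 1 to compound 2 (0.65 log units; beyond the scatter); this result is the first reading on the chain itself, and the end of the chain is so far the place where a change has left the number inside the scatter, while the configuration at the saturated chain carbon is the place where it has moved beyond it. Nothing given here bears on why this lengthening has so little effect in this assay.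

The compounds shown leave open whether a longer chain still, or an amine or a carboxylic acid at the end of the chain, would also stay within the scatter of compound 1. They also leave open whether the configuration step seen with the shorter chain would carry over to the chain of compound 3.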